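The source may report more compounds than this note shows. Statements on the series, on what has been measured and on what is new or still open speak of the compounds shown alone.

Compound 1, `CCC1=C(O)c2c(oc(-c3ccc(CC(C)C)cc3)cc2=O)C(CC)(CC)C1=O`, in a functional assay on KBVIN cells (Homo sapiens) for antiproliferative activity, read by sulforhodamine B assay, with a stated time of 3 days; a higher number here means that more compound is needed for the effect, a lower number that less compound is needed: 17.4 uM
Compound 2, `CCCOc1ccc(-c2cc(=O)c3c(o2)C(CC)(CC)C(=O)C(CC)=C3O)cc1`: 29.2 uM
Compound 3, `CCC1=C(O)c2c(oc(-c3ccc(COC)cc3)cc2=O)C(CC)(CC)C1=O`: 3.4 uM

Compound 3 has the lowest number of the three in this assay. Its nearest neighbour is compound 1, with a 5.1-fold lower number from compound 1 to compound 3 (0.71 log units; beyond the scatter); its furthest is compound 2, with an 8.6-fold lower number from compound 2 to compound 3 (0.93 log units; beyond the scatter). Between the two higher values the gap is small, a 1.7-fold higher number from compound 1 to compound 2 (0.22 log units; within the scatter).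

Compound 4, `CCC1=C(O)c2c(oc(-c3cc(C)ccc3F)cc2=O)C(CC)(CC)C1=O`, is the next step from compound 3: 2-fluoro-5-methylphenyl in place of 4-(methoxymethyl)phenyl on an aromatic carbon. Among the measured compounds shown here, none of the measured steps replaces the aryl group by one with a different substitution pattern, so no step bears on the change directly. What the steps from compound 1 and compound 2 to compound 3 do show is that altering the substituent on this aryl ring moves the number modestly, and that the 4-(methoxymethyl)phenyl group gives the lowest value seen. With that group gone and a 2-fluoro-5-methylphenyl group in its place, compound 4 is expected to give a higher number, a 2.9-fold higher number from compound 3 to compound 4 (0.47 log units; beyond the scatter), in this assay. The estimate for compound 4 is 10 uM, with a range from 3 uM to 30 uM.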

Compound 4, concentration for half-maximal effect: 3.24 uM
For compound 4 the middle estimate is 3.1-fold (0.49 log units) above the measured one; the measured number falls inside the stated range.
By their numbers in this assay, from the lowest: compounds 4 and 3 (each within the scatter of the next); then compounds 1 and 2 (each within the scatter of the next).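

In this assay, placing 2-fluoro-5-methylphenyl where 4-(methoxymethyl)phenyl stood gives a 1.0-fold lower number from compound 3 to compound 4 (0.02 log units; within the scatter) and so leaves the number unchanged within the scatter. The earlier compounds had shown the low number only with 4-(methoxymethyl)phenyl at this position, whereas compound 4 shows that this group is not the only one that reaches it, even though the entering group has a different substitution pattern and a fluorine in place of an oxygen. No measurement shown here accounts for the match between these two aryl groups.

The compounds shown leave open whether the 2-fluoro or the 5-methyl substituent matters more for the number in compound 4. They also leave open how an amine or a carboxylic acid on this aryl ring would fare.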